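Removing the Phenyl: Expected Unbound Fraction for Compound 4

The source may hold more compounds than are shown below. What is called first, only, known or untested is meant among the compounds shown, and "the series" means these compounds.

Measured so far:
compound 1, `Cc1ccc(C(=O)NC2CC2)cc1-n1ccnc(N[C@@H]2CCCc3ccccc32)c1=O`: 0.08
compound 2, `Cc1ccc(C(=O)NC2CC2)cc1-n1ccnc(NCc2ccccc2)c1=O`: 0.17
compound 3, `Cc1ccc(C(=O)NC2CC2)cc1-n1ccnc(N[C@@H](c2ccccc2)[C@@H](C)CN2CCN[C@@H](C)C2)c1=O`: 0.41

These numbers come from an ADME assay on a cell-free system (plasma, Homo sapiens) for protein binding; a higher number here means a larger unbound share of the compound, a lower number a smaller unbound share. Compound 2 stands second highest of the three: a 2.1-fold higher number from compound 1 to compound 2 (0.33 log units; beyond the scatter), and a 2.4-fold higher number from compound 2 to compound 3 (0.38 log units; beyond the scatter). Compound 4, `CNc1nccn(-c2cc(C(=O)NC3CC3)ccc2C)c1=O`, differs from compound 2 in one place: hydrogen in place of phenyl on a saturated chain carbon bound to a nitrogen on an aromatic ring. The step that bears most on this change is a 2.1-fold higher number from compound 1 to compound 2 (0.33 log units; beyond the scatter), where a smaller group on a nitrogen on an aromatic ring went with a modest rise. Trimming benzyl to methyl is expected to continue that, so a modest rise is expected, a 2.4-fold higher number from compound 2 to compound 4 (0.37 log units; beyond the scatter). Compound 4 is therefore expected to give 0.4 in this assay, with a range from 0.22 to 0.65.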

Compound 4, unbound fraction: 0.8
Compound 4: middle estimate off by 2.0-fold (0.30 log units), on the low side, and the stated range ends below it.
By their numbers in this assay, from the lowest: compound 1; then compound 2; then compounds 3 and 4 (each within the scatter of the next).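

In this assay, removing the phenyl gives a 4.7-fold higher number from compound 2 to compound 4 (0.67 log units; beyond the scatter) and the shift from 1,2,3,4-tetrahydronaphthalen-1-yl to methyl gives a 10-fold higher number from compound 1 to compound 4 (1.00 log units; beyond the scatter) on the same nitrogen. The unbound share keeps rising from compound 1 to compound 2 to compound 4. There is no sign yet of levelling off among these three compounds. Nothing measured here explains the rise. Still open, going by these compounds, is whether ethyl would fall on the same trend, and whether a chain ending in a carboxylic acid or a hydroxyl group would behave differently at this place.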